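Swapping the Aryl Ring on a Shared Core

The source may hold more compounds than are shown below. What is called first, only, known or untested is meant among the compounds shown, and "the series" means these compounds.

The measured compounds, each in an assay on isolated protein for inhibition of acid ceramidase (Homo sapiens), read by LC-MS, with a stated time of 1 h; a higher number here means a weaker inhibitor, a lower number a stronger inhibitor:
compound 1, `O=C(NCCCCc1ccccc1)n1cc(-c2ccc(Cl)cc2)oc1=O`, 83 nM;
compound 2, `COc1cccc(-c2cn(C(=O)NCCCCc3ccccc3)c(=O)o2)c1`, 341 nM;
compound 3, `O=C(NCCCCc1ccccc1)n1cc(-c2cccnc2)oc1=O`, 70 nM.

Compound 3 gives the lowest of the three numbers in this assay. Its nearest neighbour is compound 1, since a 1.2-fold lower number from compound 1 to compound 3 (0.07 log units; within the scatter) lies within the scatter, so the two cannot be ordered. Compound 2 stands apart: a 4.9-fold lower number from compound 2 to compound 3 (0.69 log units; beyond the scatter) is beyond the scatter, as is a 4.1-fold higher number from compound 1 to compound 2 (0.61 log units; beyond the scatter).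

Compound 4, `O=C(NCCCCc1ccccc1)n1cc(-c2nccs2)oc1=O`, differs from compound 3 in one place: 1,3-thiazol-2-yl in place of pyridin-3-yl on an aromatic carbon. Among the measured compounds shown here, no measured step exchanges a six-membered ring for a five-membered one at this position, so none bears on it directly. What the measured steps show is that the ring at this position does matter, but only modestly: the largest shift seen is a 4.9-fold lower number from compound 2 to compound 3 (0.69 log units; beyond the scatter), while the exchange of 4-chlorophenyl for pyridin-3-yl moved the number by no more than the scatter. A step of similar modest size, in either direction, is therefore the most that is expected here, with a slight lean towards a higher number. Compound 4 is estimated at 120 nM in this assay, within a range from 40 nM to 400 nM, which means an expected step of a 1.7-fold higher number from compound 3 to compound 4 (0.23 log units; within the scatter).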

Compound 4, half-maximal inhibitory concentration: 59 nM
For compound 4 the middle estimate is 2.0-fold (0.31 log units) above the measured one; measured number inside the range.
By their numbers in this assay, from the lowest: compounds 4, 3 and 1 (each within the scatter of the next); then compound 2.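

With 1,3-thiazol-2-yl on the aromatic carbon next to the ring oxygen, a five-membered aromatic ring with 2 hetero atoms takes the place of a six-membered one, and in this assay the change cannot be told from the scatter: a 1.2-fold lower number from compound 3 to compound 4 (0.07 log units; within the scatter). The same holds against the 4-chlorophenyl compound, with a 1.4-fold lower number from compound 1 to compound 4 (0.15 log units; within the scatter), so compounds 1, 3 and 4 form one group despite the difference in ring size and hetero atoms, while a 5.8-fold lower number from compound 2 to compound 4 (0.76 log units; beyond the scatter) keeps compound 2, with its 3-methoxyphenyl group, apart from this new compound as well. No evidence accompanies these numbers to say what lies behind either result.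

The compounds shown leave open whether the separation of compound 2 belongs to the methoxy group itself or to where it sits on the ring, which a 4-methoxyphenyl group at the same place would address. They also leave open whether this position needs an aromatic ring at all, as a plain methyl group would show, and whether a carboxylic acid or an amine carried on the 1,3-thiazol-2-yl ring would keep the number in the same range.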